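Cytotoxicity of a third amide at the limit

This account rests on a few compounds, and the source may have more. Where it says the series, first, only, none or still open, it means among the compounds named here.

Measured so far (an ADME assay on SH-SY5Y cells (Homo sapiens) for cytotoxicity, read by MTT assay, with a stated time of 48 h; a higher number here means a weaker inhibitor, a lower number a stronger inhibitor)
Compound 1 (`COc1ccc(C(=O)/C=C/c2ccc(C(=O)N3CCCCC3)cc2)c(O)c1`) reads > 100000 nM as a limit, not a number
Compound 2 (`COc1ccc(C(=O)/C=C/c2ccc(C(=O)Nc3ccccc3OC)cc2)c(O)c1`) reads > 100000 nM as a limit, not a number

Compound 2 has no exact position on the scale, only a limit. It shares that position with the other measured compound, as the evidence shows (the limit of > 100000 nM in this assay, at which 2 of the 2 values shown sit). Compound 3 (`COc1ccc(C(=O)/C=C/c2ccc(C(=O)Nc3ccc(C)cc3C)cc2)c(O)c1`) differs from compound 2 in one place, with 2,4-dimethylphenyl in place of 2-methoxyphenyl on an amide-type nitrogen.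

For the measured compounds named here, the one measured step that bears on this change is a step that the two limits leave unreadable from compound 1 to compound 2 and it offers no size to carry over. The expectation therefore rests on compound 2 with its limit of > 100000 nM and no step beyond the scatter is expected in this assay in either direction. Compound 3 is more likely than not to be reported as a limit as well. The estimated change is a step that the limit leaves unreadable from compound 2 to compound 3 and it is expected to remain within the scatter. For compound 3 the expected value is 150000 nM (estimated range 60000 nM to 400000 nM).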

Compound 3, half-maximal inhibitory concentration: > 100000 nM
Compound 3: only a limit was reported; the forecaster's own chance of this, stated with the estimate: 80%; the middle value is on the limit's open side.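

In this assay, for the compounds shown here, compound 3 is reported as a limit, not a number, as are compound 1 and compound 2, so no step among the three can be read. The compounds shown leave open how far each true value lies past that limit and whether the three amides differ at all, since all sit together: the limit of > 100000 nM in this assay, at which 3 of the 3 values shown sit.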